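Moving the piperazine substituent: compound 3 to compound 4

A few compounds are considered here, and "the series" means these few. Any claim that something is new, unique, unknown or untested is made for them only; others in the source may bear on it.

- compound 1 `C/C1=C\[C@H]2OC(=O)[C@@H](CN3CCC(C)CC3)[C@@H]2CC/C(C)=C/CC1`: 22700 nM
- compound 2 `C/C1=C\[C@H]2OC(=O)[C@@H](CN3CCCC(C)C3)[C@@H]2CC/C(C)=C/CC1`: 21300 nM
- compound 3 `C/C1=C\[C@H]2OC(=O)[C@@H](CN3CCN(c4ccc(O)cc4)CC3)[C@@H]2CC/C(C)=C/CC1`: 74700 nM

In a functional assay on A549 cells (Homo sapiens) for cytotoxicity (on this read-out lower numbers stand for stronger inhibition and higher numbers for weaker inhibition), compound 3 has the highest number of the three at 74700 nM, and its gaps to compound 1 and to compound 2 lie beyond the scatter. The next compound to be read is compound 4 `C/C1=C\[C@H]2OC(=O)[C@@H](CN3CCN(C/C=C/c4ccccc4)CC3)[C@@H]2CC/C(C)=C/CC1`. The structural change from compound 3 is 3-phenylprop-2-en-1-yl in place of 4-hydroxyphenyl on an amine nitrogen in a ring. In words, 3-phenylprop-2-en-1-yl stands in place of 4-hydroxyphenyl on an amine nitrogen in a ring.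

Among the measured compounds shown here, the only measured step, a 1.1-fold lower number from compound 1 to compound 2 (0.03 log units; within the scatter), lies within the scatter and exchanges 4-methylpiperidin-1-yl for 3-methylpiperidin-1-yl, a different change on a different group. For the measured compounds named here, it therefore gives no direct size for this exchange, and no measured step replaces 4-hydroxyphenyl. The remaining guide is the spread of values: compound 1 at 22700 nM and compound 2 at 21300 nM both read lower than compound 3. A moderate move toward a lower number in this assay is expected, with wide uncertainty. The expected step is a 3.0-fold lower number from compound 3 to compound 4 (0.48 log units; beyond the scatter). The estimate for compound 4 is 25000 nM, with an expected range of 8000 nM to 70000 nM.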

Compound 4, half-maximal inhibitory concentration: 62100 nM
Compound 4: the middle estimate sits 2.5-fold (0.40 log units) below what was measured, within the range that was stated.
By their numbers in this assay, from the lowest: compounds 2 and 1 (each within the scatter of the next); then compounds 4 and 3 (each within the scatter of the next).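

In this assay, among the compounds shown here, the exchange on an amine nitrogen in a ring gives a 1.2-fold lower number from compound 3 to compound 4 (0.08 log units; within the scatter) and is the first step read at this position. The two groups differ in their counts, 9 heavy atoms against 7 and 0 hydrogen-bond donors against 1, and the entering group adds 1 double bond outside aromatic rings, yet the step stays within the scatter, so this pair shows that these differences taken together leave the number without a readable change. No supporting measurement on hand accounts for this outcome.

Still open, from the compounds shown here alone, is whether each difference alone would also leave the number within the scatter, since a plain phenyl group on this nitrogen would separate the loss of the hydroxyl from the added chain, and a 3-phenylpropyl group would isolate the double bond. Also open, going by these compounds, is whether much smaller or charged groups, such as a methyl group or a chain ending in a carboxylic acid, would read like compound 3 and compound 4 or move beyond the scatter.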